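Notes on the carbonyl substituent of the shared core

The source may hold more compounds than are shown below. What is called first, only, known or untested is meant among the compounds shown, and "the series" means these compounds.

Measured so far in a functional assay on ileum for antagonist activity at histamine H1 receptor (Cavia porcellus); on this read-out lower numbers stand for tighter binding and higher numbers for weaker binding:
compound 1 `CCC(=O)/N=C(\N)NCCCc1c[nH]cn1`: 5130 nM
compound 2 `CC(=O)/N=C(\N)NCCCc1c[nH]cn1`: 8510 nM
compound 3 `CN(CCC(=O)/N=C(\N)NCCCc1c[nH]cn1)C(=O)c1cc2ccccc2[nH]1`: 3020 nM

Compound 2 gives the highest of the three numbers in this assay. Its nearest neighbour is compound 1; the step of a 1.7-fold higher number from compound 1 to compound 2 (0.22 log units; within the scatter) lies within the scatter, so the two cannot be ordered. Compound 3 stands furthest from it, and the two values of compound 2 and compound 3 differ beyond the scatter.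

Compound 4 `CC(C)C(=O)/N=C(\N)NCCCc1c[nH]cn1` has not yet been measured. It differs from compound 2 in one place: isopropyl in place of methyl on a carbonyl carbon. Among the compounds with values here, the only measured step that bears on this change is a 1.7-fold higher number from compound 1 to compound 2 (0.22 log units; within the scatter), which alters the same carbonyl substituent by one chain carbon and stays within the scatter. Read in the opposite direction it points to a somewhat lower number for a larger group, but the size of that step gives no ground to expect anything beyond the scatter for compound 4.

Accordingly compound 4 is expected to show a 1.9-fold lower number from compound 2 to compound 4 (0.28 log units; within the scatter) in this assay, an estimated 4500 nM with a range from 1600 nM to 12000 nM.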

Compound 4, dissociation constant: 7760 nM
Estimate against measurement, compound 4: 1.7-fold (0.24 log units) below; the measured number falls inside the stated range.
By their numbers in this assay, from the lowest: compounds 3, 1, 4 and 2 (each within the scatter of the next, the first and the last beyond it).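

In this assay, isopropyl in place of methyl on a carbonyl carbon gives a 1.1-fold lower number from compound 2 to compound 4 (0.04 log units; within the scatter), and methyl in place of hydrogen on the saturated chain carbon gives a 1.5-fold higher number from compound 1 to compound 4 (0.18 log units; within the scatter), so both new steps stay within the scatter. Compound 1, compound 2 and compound 4 therefore cannot be ordered, and the position now shows no readable change for a branched isopropyl group as well as for the one-carbon chain step seen earlier. No supporting data are available to account for this flat result.

Still open, going by these compounds, is whether a longer chain, a phenyl ring or an amine on this carbonyl carbon would move the number beyond the scatter. Compound 3 differs from the others in more than one place, so the contribution of its substituent cannot be separated here.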